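Swapping a Halogen on the Sulfonyl Aryl Ring

The source may hold more compounds than are shown below. What is called first, only, known or untested is meant among the compounds shown, and "the series" means these compounds.

Measured compounds:
- Compound 1, `O=C1/C(=C/c2cccnc2)CN(S(=O)(=O)c2ccc(F)cc2)C/C1=C\c1ccccc1F`: 15600 nM
- Compound 2, `O=C1/C(=C/c2cccnc2)CN(S(=O)(=O)c2ccc(Cl)cc2)C/C1=C\c1ccccc1F`: 12400 nM
- Compound 3, `O=C1/C(=C/c2ccncc2)CN(S(=O)(=O)c2ccc(F)cc2)C/C1=C\c1ccccc1F`: 20300 nM

All three were tested in a functional assay on HepG2 cells (Homo sapiens) for cytotoxicity, read by MTT assay, with a stated time of 24 h; on this read-out higher numbers stand for weaker inhibition and lower numbers for stronger inhibition. Compound 1 gives 15600 nM there, and compound 2 gives 12400 nM. The two differ only in one spot, (chloro in place of fluoro on an aromatic carbon), and the step is a 1.3-fold lower number from compound 1 to compound 2 (0.10 log units; within the scatter), so the two readings cannot be told apart. Compound 3 gives 20300 nM in this assay. Its core differs from that of compound 1 as pyridin-4-yl in place of pyridin-3-yl on a double-bonded chain carbon bound to a double-bonded ring carbon, and the step is a 1.3-fold higher number from compound 1 to compound 3 (0.11 log units; within the scatter), again a gap that repeated measurements would blur. Among the measured compounds shown here, no step between compound 2 and compound 3 is worked out here; their two values simply sit close together.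

Compound 4, `O=C1/C(=C/c2ccncc2)CN(S(=O)(=O)c2ccc(Cl)cc2)C/C1=C\c1ccccc1F`, has not yet been measured. It differs from compound 3 as chloro in place of fluoro on an aromatic carbon. The place of this change is described in exactly the same words as for the move from compound 1 to compound 2, so it is the same change, made on the other core. Since that change produced a 1.3-fold lower number from compound 1 to compound 2 (0.10 log units; within the scatter), the expectation for compound 4 is a step of about a 1.3-fold lower number from compound 3 to compound 4 (0.10 log units; within the scatter), which is small and inside the usual scatter. Compound 4 is therefore expected to give roughly 16000 nM in this assay, most likely between 9000 nM and 30000 nM.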

Compound 4, half-maximal inhibitory concentration: 5300 nM
The estimate for compound 4 lay 3.0-fold (0.48 log units) above the measured number; measured number outside the range, below it.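

On the core of compound 3, chloro in place of fluoro gives a 3.8-fold lower number from compound 3 to compound 4 (0.58 log units; beyond the scatter) in this assay, and this change does not carry over with the same size from one core to the other: the same change on two cores in this assay, a 1.3-fold lower number (0.10 log units; within the scatter) from compound 1 to compound 2 and a 3.8-fold lower number (0.58 log units; beyond the scatter) from compound 3 to compound 4, 3.0-fold (0.48 log units) apart, beyond the scatter of two such steps. Read the other way, pyridin-4-yl in place of pyridin-3-yl gives a 2.3-fold lower number from compound 2 to compound 4 (0.37 log units; beyond the scatter) when the chloro group is present, whereas with the fluoro group the same swap stays within the scatter, so the effect of each change depends on the other: the same change on two cores in this assay, a 1.3-fold higher number (0.11 log units; within the scatter) from compound 1 to compound 3 and a 2.3-fold lower number (0.37 log units; beyond the scatter) from compound 2 to compound 4, 3.0-fold (0.48 log units) apart, beyond the scatter of two such steps. These four compounds show this dependence only as a single set of two changes in one cytotoxicity read-out; they do not show why it arises, and they do not show that a halogen swap would behave the same way on any further core.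

On these data alone, it remains open whether a bromo, methyl or methoxy group in place of the halogen would follow chloro or fluoro on each of the two cores. As far as these compounds go, it is also open whether a pyridin-2-yl group in place of the other two pyridine groups would show the same dependence on the halogen.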